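Nitrophenylpiperazines: hydroxy to benzylamino on compound 2

A few compounds are considered here, and "the series" means these few. Any claim that something is new, unique, unknown or untested is made for them only; others in the source may bear on it.

Of the compounds shown here, three have been measured in an assay on isolated protein for inhibition of NAD-dependent protein deacylase sirtuin-6 (Homo sapiens), tested at 300 uM; on this read-out lower numbers stand for less inhibition and higher numbers for more inhibition at the one concentration tested (going by the name of the read-out). Compound 1 `Cc1cc(C)cc(C(=O)Nc2ccc(N3CCN(C)CC3)cc2)c1`, the amide-linked member, gives 26.2% in this assay. Compound 3 `CCN1CCN(c2ccc([N+](=O)[O-])cc2)CC1` gives 69.7% and differs from compound 2 in more than one place. Compound 2 `CN1CCN(c2ccc([N+](=O)[O-])c(O)c2)CC1` gives 119%, the highest of the three numbers; compound 3 lies nearest, with a gap beyond the scatter, and compound 1 lies furthest, also beyond the scatter.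

Compound 4 `CN1CCN(c2ccc([N+](=O)[O-])c(NCc3ccccc3)c2)CC1` has not yet been measured. It differs from compound 2 in a single place: benzylamino in place of hydroxy on an aromatic carbon. Within the data shown here, no pair of measured compounds shows this change on its own, so the size of the step cannot be read off directly and the other two numbers give only a rough frame. Compound 3, which lacks the hydroxy group, sits well under compound 2, while compound 1 sits lower still.

On that footing the step from compound 2 to compound 4 in this assay is expected to be downward and beyond the scatter, a number 34 percentage points lower from compound 2 to compound 4 (beyond the scatter), though with wide uncertainty. Compound 4 is therefore estimated at 85%, within a range from 45% to 120%.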

Compound 4, a percentage reported as inhibition, at one concentration (the size of the read-out at that concentration, not a potency): 96%
Estimate against measurement, compound 4: 11 percentage points below; measured number inside the range.
By their numbers in this assay, from the lowest: compound 1; then compound 3; then compound 4; then compound 2.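

In this assay, among these compounds, replacing hydroxy with benzylamino gives a number 23 percentage points lower from compound 2 to compound 4 (beyond the scatter), the first step in which a single change can be read on its own. The step shows that this aromatic carbon, ortho to a nitro group, can carry a substituent of 8 heavy atoms, including a six-membered aromatic ring of carbon only, in place of a single oxygen while compound 4 still gives 96%, so the drop is real but modest for so large an addition. No supporting data bear on the origin of this drop.

The single step combines two changes, the exchange of oxygen for nitrogen at the ring carbon and the addition of the benzyl group, and the compounds shown do not separate them; a plain amino group or a methylamino group at this carbon would address that split. Also open, from the compounds shown here alone, is how much of the remaining inhibition depends on the benzyl ring itself, which a phenethylamino group with its longer chain, or a chlorine or methoxy group on the benzyl ring, would begin to test.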